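This account rests on a few compounds, and the source may have more. Where it says the series, first, only, none or still open, it means among the compounds named here.

Measured in a functional assay on U-937 cells (Homo sapiens) for inhibition, read by scintillation counting, with a stated time of 15 min; a higher number here means a weaker inhibitor, a lower number a stronger inhibitor:
- Compound 1 `O=C(NC1CCCCCC1)c1c(-c2ccccc2)c(Br)cn(Cc2ccc(F)cc2)c1=O`: > 10000 nM
- Compound 2 `O=C(NC1CCCCCC1)c1c(-c2ccccc2)ccn(Cc2ccc(F)cc2)c1=O`: > 10000 nM

Each of these two values is a limit, not a number. Compound 1 therefore has no readable potency, and the limit of > 10000 nM in this assay, at which 2 of the 2 values shown sit, describes the whole of the measured series.

Compound 3 `Cc1c(Br)cn(Cc2ccc(F)cc2)c(=O)c1C(=O)NC1CCCCCC1` keeps the core of compound 1 but carries methyl in place of phenyl on an aromatic carbon. Among the compounds with values here, the only measured step is a step that the two limits leave unreadable from compound 1 to compound 2. It changes a different place, the bromo group, and gives no size to carry over. Within the data shown here, no measured step tests the phenyl group.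

The expectation is therefore loose. Only a change towards stronger inhibition could be read, and another limit remains quite possible. The estimated step is an at least 3.3-fold lower number from compound 1 to compound 3 (0.52 log units; beyond the scatter).

For compound 3 the expected value is 3000 nM, with an estimated range of 150 nM to 10000 nM.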

Compound 3, half-maximal inhibitory concentration: 930 nM
Beside the measured number, compound 3's estimate is 3.2-fold (0.51 log units) above it; measured number inside the range.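

Swapping phenyl for methyl on the aromatic carbon opposite the ring nitrogen gives an at least 10-fold lower number from compound 1 to compound 3 (1.03 log units; beyond the scatter) in this assay, and compound 3 is the only compound shown with a readable potency. Compound 1 holds a limit and not a number, so this step sets only a lower bound on the change. Among the compounds shown, this position is the only place where a change yields a measured value, while the rest of the series stays at the limit: the limit of > 10000 nM in this assay, at which 2 of the 3 values shown sit.

On these data alone, only phenyl and methyl appear at this position, so the outcome with ethyl, a longer chain or an amine there remains open. Also open, as far as these compounds go, is whether the methyl group gives a readable value when hydrogen stands in place of the bromo group.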